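Chloro for methyl beside the carboxy group: compound 4

A few compounds are considered here, and "the series" means these few. Any claim that something is new, unique, unknown or untested is made for them only; others in the source may bear on it.

Measured compounds:
compound 1, `Cc1c(OC[C@@H](C)COc2ccc(Cl)c(C(=O)O)c2)ccc(C(=O)CC(C)(C)C)c1O`, gives 2200 nM in an assay for positive allosteric modulation of metabotropic glutamate receptor 3 (Rattus norvegicus); a lower number here means that less compound is needed, a higher number that more compound is needed for the effect;
compound 2, `Cc1c(OC[C@@H](C)COc2ccc(C(=O)O)cc2Cl)ccc(C(=O)CC(C)(C)C)c1O`, gives 1650 nM;
compound 3, `Cc1cc(OC[C@H](C)COc2ccc(C(=O)CC(C)(C)C)c(O)c2C)ccc1C(=O)O`, gives 1350 nM.

Compound 3 stands at the low end of the three numbers, but the steps of a 1.6-fold lower number from compound 1 to compound 3 (0.21 log units; within the scatter) and a 1.2-fold lower number from compound 2 to compound 3 (0.09 log units; within the scatter) are both within the scatter, as is a 1.3-fold lower number from compound 1 to compound 2 (0.12 log units; within the scatter). All three measured steps rearrange the substituents of the carboxyphenyl group on the oxygen on a saturated carbon, and none moves the number beyond the scatter.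

Compound 4, `Cc1c(OC[C@@H](C)COc2ccc(C(=O)O)c(Cl)c2)ccc(C(=O)CC(C)(C)C)c1O`, differs from compound 3 by chloro in place of methyl on an aromatic carbon. Among the measured compounds shown here, no measured step swaps chloro for methyl at one and the same position, so the bearing of the three steps is indirect: they show that shifting chloro, methyl and carboxy around this ring left the number nearly unchanged. The step of a 1.1-fold higher number from compound 3 to compound 4 (0.05 log units; within the scatter) is therefore expected to stay within the scatter. Compound 4 is estimated at 1500 nM, in a range from 700 nM to 3200 nM.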

Compound 4, half-maximal effective concentration: 860 nM
Estimate against measurement, compound 4: 1.7-fold (0.24 log units) above; the range from low to high includes it.
By their numbers in this assay, from the lowest: compounds 4, 3, 2 and 1 (each within the scatter of the next, the first and the last beyond it).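

In this assay, among the compounds shown here, chloro in place of methyl on the aromatic carbon ortho to a carboxy group gives a 1.6-fold lower number from compound 3 to compound 4 (0.20 log units; within the scatter), the first comparison of these two groups at one position, and it does not separate them. 4-Carboxy-3-chlorophenyl in place of 4-carboxy-2-chlorophenyl gives a 1.9-fold lower number from compound 2 to compound 4 (0.28 log units; within the scatter), so this shift of the chloro does not separate the two compounds either. 4-Carboxy-3-chlorophenyl in place of 3-carboxy-4-chlorophenyl gives a 2.6-fold lower number from compound 1 to compound 4 (0.41 log units; beyond the scatter), a modest step but the first in this set beyond the scatter, in which carboxy and chloro trade places.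

Nothing in the data shown accounts for this step. Going by these compounds, whether fluoro, methoxy or an amine at the position ortho to the carboxy group would also stay within the scatter of chloro and methyl remains open.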